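Dropping the chloro from compound 2

The compounds below may be only part of what the source reports. "The series", "measured", "known", "first", "only" and "open" are said of these compounds alone.

Of the compounds shown here, two have numbers so far. In a functional assay on HCT-116 cells (Homo sapiens) for inhibition, read by MTT assay, with a stated time of 48 h (a lower number here means a stronger inhibitor, a higher number a weaker inhibitor), compound 1 (`COc1ccc(CN(C(=O)C(C)Br)c2cc(OC)c(OC)c(OC)c2)cc1O`) gives 140 nM and compound 2 (`COc1ccc(CNc2cc(OC)c(OC)c(OC)c2)cc1Cl`) gives 41700 nM. Compound 2 therefore holds the higher of the two numbers, and the gap to compound 1 lies beyond the scatter. The two compounds differ in more than one place, so this gap says nothing about the chloro alone.

The next compound is compound 3 (`COc1ccc(CNc2cc(OC)c(OC)c(OC)c2)cc1`). Relative to compound 2, the change is hydrogen in place of chloro on an aromatic carbon. Among the compounds with values here, no measured pair isolates this change, so the expectation rests on the structures and on the weak standing of compound 2 at 41700 nM. In this assay the expected outcome is no shift beyond the scatter, with an estimated 1.0-fold lower number from compound 2 to compound 3 (0.02 log units; within the scatter). The estimated value for compound 3 is 40000 nM, within an expected range of 15000 nM to 100000 nM.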

Compound 3, half-maximal inhibitory concentration: 18400 nM
Compound 3: the middle estimate sits 2.2-fold (0.34 log units) above what was measured, and the stated range covers the measured number.
By their numbers in this assay, from the lowest: compound 1; then compound 3; then compound 2.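

In this assay the series now has its first comparison that isolates one place: replacing chloro with hydrogen on the aromatic carbon ortho to a methoxy group gives a 2.3-fold lower number from compound 2 to compound 3 (0.36 log units; beyond the scatter). Within this pair, the chloro is therefore not required for activity at this position, and the hydrogen-bearing compound carries the lower number. The step is modest but lies beyond the usual scatter, so this aromatic carbon has a small, readable influence on the number in the secondary-amine setting shared by the pair, and no measurement at hand bears on the reason for the shift.

The compounds shown leave open whether the trend extends to other groups at this carbon, such as fluoro, methyl, nitrile or an amine, since chloro and hydrogen give only two points at this position. Steps to compound 1 cannot be read because it differs from the other compounds in more than one place, so it remains unknown whether the same replacement would have a similar effect on its core.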